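This account rests on a few compounds, and the source may have more. Where it says the series, first, only, none or still open, it means among the compounds named here.

Compound 2 `C=C1CC[C@@H]2[C@](C)(CCC[C@]2(C)C(=O)O)[C@H]1C/C=C(\C)C=O` is one of three members of the series measured in a functional assay on SMMC-7721 cells (Homo sapiens) for cytotoxicity, read by MTT assay, with a stated time of 48 h; on this read-out higher numbers stand for weaker inhibition and lower numbers for stronger inhibition. In this assay compound 2 returns only a limit, > 40000 nM. Compound 1 `C=CC(=C)[C@@H](O)C[C@H]1C(=C)CC[C@@H]2[C@]1(C)CCC[C@]2(C)C(=O)O` likewise returns only a limit in this assay, > 40000 nM. Compound 3 `C=CC(=C)CC[C@@H]1[C@@]2(C)CCC[C@](C)(COC(=O)/C=C/c3ccc(O)c(OC)c3)[C@@H]2CC[C@@]1(C)O`, which differs from both in several places, gives 14100 nM in this assay. Among the compounds with values here, the single one-place step on record, a step that the two limits leave unreadable from compound 1 to compound 2, cannot be sized, since the limit of > 40000 nM in this assay, at which 2 of the 3 values shown sit, holds both of its ends. Compound 4 `C=CC(=C)[C@H](O)C[C@H]1C(=C)CC[C@@H]2[C@]1(C)CCC[C@]2(C)C(=O)O` is not yet measured; it differs from compound 2 by a group of 6 heavy atoms (5 carbon, 1 oxygen; no ring) in place of a group of 5 heavy atoms (4 carbon, 1 oxygen; no ring), on a saturated chain carbon bound to a saturated ring carbon, the same exchange that separates compound 1 from compound 2, with the stereocentre set the other way. Within the data shown here, no measured step therefore gives a size or a direction for this change, and neither neighbour supplies a number. For compound 4 the expected step is a step that the limit leaves unreadable from compound 2 to compound 4, nothing beyond the scatter. Given (the limit of > 40000 nM in this assay, at which 2 of the 3 values shown sit), compound 4 is expected to give 50000 nM, within 20000 nM to 150000 nM, most probably reported again as a limit only.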

Compound 4, half-maximal inhibitory concentration: > 40000 nM
Compound 4: no number, only a limit; the forecaster's own chance of this, stated with the estimate: 80%; the middle value lies beyond the limit too.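

No step can be read among compound 1, compound 2 and compound 4 in this assay, since all three sit at one limit: the limit of > 40000 nM in this assay, at which 3 of the 4 values shown sit. Whether the stereocentre at the saturated chain carbon affects cytotoxicity stays open, with only limits on both sides of this pair: the fact that compounds 1 and 4 differ only in the configuration as drawn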